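The source may hold more compounds than are shown below. What is called first, only, known or untested is meant among the compounds shown, and "the series" means these compounds.

Compound 1, `Cc1ccccc1-n1nc(-c2ccccc2)nc1CNc1ccc(C(=O)NO)cc1`, gives 57.1% in an assay on Sf9 cells for inhibition of protein deacetylase HDAC6 (Homo sapiens), read by fluorescence, with a stated time of 40 min, tested at 100 nM; a lower number here means less inhibition, a higher number more inhibition at the concentration tested (going by the name of the read-out).
Compound 2, `O=C(NO)c1ccc(NCc2nc(-c3ccc(Br)o3)nn2-c2ccccc2)cc1`, gives 55.8% in this assay.
Compound 3, `COc1ccc(-n2nc(-c3ccccc3)nc2CNc2ccc(C(=O)NO)cc2)cc1`, gives 63.4% in this assay.

Of these three numbers, that of compound 2 is the lowest on the page, yet its gap to compound 1 and its gap to compound 3 both lie within the usual scatter of repeated measurements, so the three compounds cannot be told apart by these readings.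

Compound 4, `O=C(NO)c1ccc(NCc2nc(-c3cccc4cnccc34)nn2-c2ccccc2)cc1`, has not yet been measured. It differs from compound 2 in one place: isoquinolin-5-yl in place of 5-bromofuran-2-yl on an aromatic carbon. Among the compounds with values here, the only measured step is a number 6.3 percentage points higher from compound 1 to compound 3 (within the scatter), which swaps the group on an aromatic nitrogen, not on the aromatic carbon between two ring nitrogens, and it stayed within the scatter. Within the data shown here, no measured step changes the group at the place where compound 4 differs from compound 2, so there is no direct guide for it. With all three measured numbers sitting close together, the expectation is that replacing the group on this carbon produces no step beyond the scatter, so the estimated step is a number 1.2 percentage points higher from compound 2 to compound 4 (within the scatter). Compound 4 is therefore expected to give about 57% in this assay, within a range from 40% to 72%.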

Compound 4, a percentage reported as inhibition, at one concentration (the size of the read-out at that concentration, not a potency): 40.2%
For compound 4 the middle estimate is 16.8 percentage points above the measured one, within the range that was stated.
By their numbers in this assay, from the lowest: compound 4; then compounds 2, 1 and 3 (each within the scatter of the next).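

Putting isoquinolin-5-yl in place of 5-bromofuran-2-yl on the aromatic carbon between two ring nitrogen atoms gives a number 15.6 percentage points lower from compound 2 to compound 4 (beyond the scatter), the first step among these compounds to clear the usual scatter in this assay. The only earlier step, a number 6.3 percentage points higher from compound 1 to compound 3 (within the scatter), changed a group on an aromatic nitrogen and could not separate its two compounds, so this carbon is the one place shown where a swap moves the reading by more than repeat measurements would. The entering group counts 10 heavy atoms in two rings against 6 heavy atoms in one ring for the group that leaves, yet no measurement offered here accounts for the step.

From the compounds shown here alone, how a much smaller group on this carbon, such as a methyl, an amine or a carboxylic acid, would read remains open, since the direct comparison here rests on just two groups. Also open, going by these compounds, is whether the same swap would give a step of similar size with 4-methoxyphenyl rather than phenyl on the aromatic nitrogen, and whether it would hold at other concentrations.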